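Cytotoxicity notes on the benzyl variation series

The source may hold more compounds than are shown below. What is called first, only, known or untested is meant among the compounds shown, and "the series" means these compounds.

Measured in an ADME assay on MT2 cells (Homo sapiens) for cytotoxicity, read by XTT assay, with a stated time of 4 days; a lower number here means that less compound is tolerated, a higher number that more compound is tolerated:
compound 1 `COC(=O)c1ccc(CN2C(=O)/C(=C/c3cc(C)n(-c4ccc(O)c(C(=O)O)c4)c3C)SC2=S)cc1`: 36900 nM
compound 2 `Cc1cc(/C=C2\SC(=S)N(Cc3cccc(C(=O)O)c3)C2=O)c(C)n1-c1ccc(O)c(C(=O)O)c1`: > 100000 nM
compound 3 `Cc1cc(/C=C2\SC(=S)N(Cc3ccccc3C(F)(F)F)C2=O)c(C)n1-c1ccc(O)c(C(=O)O)c1`: 28800 nM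

The value of compound 2 is a limit of this assay, not a number (the limit of > 100000 nM in this assay, at which 1 of the 3 values shown sits). Among the two numbers, compound 1 stands highest, with compound 3 nearest: a 1.3-fold lower number from compound 1 to compound 3 (0.11 log units; within the scatter). The other step, an at least 2.7-fold higher number from compound 1 to compound 2 (0.43 log units; beyond the scatter), is the only one beyond the scatter, and an at least 3.4-fold lower number from compound 2 to compound 3 (0.54 log units; beyond the scatter) points the same way.

Compound 4 `Cc1cc(/C=C2\SC(=S)N(Cc3ccccc3Br)C2=O)c(C)n1-c1ccc(O)c(C(=O)O)c1` differs from compound 1 by 2-bromophenyl in place of 4-(methoxycarbonyl)phenyl on a saturated chain carbon bound to an amide-type nitrogen in a ring. Within the data shown here, the step that bears on it is the one to compound 3, since a 2-(trifluoromethyl)phenyl resembles a 2-bromophenyl far more than a 3-carboxyphenyl does; that step stayed within the scatter. A step within the scatter is therefore expected, a 1.2-fold lower number from compound 1 to compound 4 (0.09 log units; within the scatter). Compound 4 is estimated at 30000 nM, between 12000 nM and 75000 nM.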

Compound 4, half-maximal cytotoxic concentration: 25700 nM
Estimate against measurement, compound 4: 1.2-fold (0.07 log units) above, within the range that was stated.
By their numbers in this assay, from the lowest: compounds 4, 3 and 1 (each within the scatter of the next). At a limit, above all of these: compound 2.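

With 2-bromophenyl at this place on the saturated chain carbon, the size of the halogen-type group makes no readable difference in this assay: a 1.1-fold lower number from compound 3 to compound 4 (0.05 log units; within the scatter), and a 1.4-fold lower number from compound 1 to compound 4 (0.16 log units; within the scatter), so the ester-bearing benzyl and both ortho-free comparisons aside, these three compounds sit together. Only the 3-carboxyphenyl stands apart, with an at least 3.8-fold lower number from compound 2 to compound 4 (0.59 log units; beyond the scatter). Compound 2 is at a limit and not a number: the limit of > 100000 nM in this assay, at which 1 of the 4 values shown sits.

Still open, from the compounds shown here alone, is whether any group other than 3-carboxyphenyl reaches that limit. Going by these compounds, how an amine on this phenyl, or a longer chain carrying it, would read in this assay also remains unknown.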